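The source may hold more compounds than are shown below. What is called first, only, known or untested is meant among the compounds shown, and "the series" means these compounds.

Of the compounds shown here, three sharing one core have been tested in an ADME assay on Akata cells (Homo sapiens) for cytotoxicity, with a stated time of 7 days; on this read-out lower numbers stand for higher toxicity in this test and higher numbers for lower toxicity in this test. Compound 1 `CCCCCCCCOc1nc(N)nc2c1ncn2/C=C1/CC1(CO)CO` carries an octyloxy group on an aromatic carbon of that core. Compound 2 `Nc1nc(NC2CC2)c2ncn(/C=C3/CC3(CO)CO)c2n1` carries a cyclopropylamino group there instead, and compound 3 `CCOc1nc(N)nc2c1ncn2/C=C1/CC1(CO)CO` an ethoxy group. In this assay compound 1 gives > 20000 nM, which is a limit of the assay rather than a number. In this assay compound 2 likewise reaches only the limit > 20000 nM. Compound 3 too gives only the limit > 20000 nM in this assay. Compound 3 therefore stands exactly where the other two stand, at the limit of > 20000 nM in this assay, at which 3 of the 3 values shown sit. The steps a step that the two limits leave unreadable from compound 1 to compound 2 and a step that the two limits leave unreadable from compound 2 to compound 3 cannot be sized.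

Compound 4 `CCCCOc1nc(N)nc2c1ncn2/C=C1/CC1(CO)CO` differs from compound 3 by a single change: ethyl in place of hydrogen on a saturated chain carbon, two bonds along the chain from an oxygen on an aromatic ring. The closest comparison is a step that the two limits leave unreadable from compound 1 to compound 3, hydrogen in place of hexyl at the same place, and it too is unreadable because both of its ends sit at the limit of > 20000 nM in this assay, at which 3 of the 3 values shown sit. Among the measured compounds shown here, no measured step gives a readable size or direction for lengthening this chain. The expected outcome for compound 4 is a step that the limit leaves unreadable from compound 3 to compound 4, nothing beyond the scatter. Compound 4 is estimated at 30000 nM, with a range from 15000 nM to 100000 nM, most likely reported again only as a limit.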

Compound 4, half-maximal cytotoxic concentration: > 20000 nM
Compound 4: a limit, no number; the forecaster's own chance of this, stated with the estimate: 85%; the middle value lies beyond the limit too.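

Compound 4 also gives only a limit, so the steps linking it to compound 1, compound 2 and compound 3 cannot be read in this assay, and all four compounds stand at the same place: the limit of > 20000 nM in this assay, at which 4 of the 4 values shown sit.

The compounds shown leave open whether octyloxy, butoxy, ethoxy and cyclopropylamino differ at all in cytotoxicity, and in which direction.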